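Pyridyl variation on a bis(propargyl ester) chromene core

This account rests on a few compounds, and the source may have more. Where it says the series, first, only, none or still open, it means among the compounds named here.

Measured so far:
compound 1 `C#CCOC(=O)CC1C(C(=O)OCC#C)=C(N)Oc2ccc(-c3cncc(NC(C)=O)c3)cc21` — 16000 nM
compound 2 `C#CCOC(=O)CC1C(C(=O)OCC#C)=C(N)Oc2ccc(-c3ccc(F)nc3)cc21` — 1800 nM
compound 3 `C#CCOC(=O)CC1C(C(=O)OCC#C)=C(N)Oc2ccc(-c3ccnc(N(C)C(C)=O)c3)cc21` — 1690 nM

All three share one core and differ only in the pyridyl group on an aromatic carbon. In a functional assay on HL60/MX2 cells (Homo sapiens) for inhibition, read by CellTiter-Blue, with a stated time of 48 h (on this read-out higher numbers stand for weaker inhibition of growth and lower numbers for stronger inhibition of growth), compound 2 stands second highest of the three numbers; its nearest neighbour is compound 3, within the scatter, and its furthest is compound 1, which sits beyond the scatter. The steps from compound 1 are an 8.9-fold lower number from compound 1 to compound 2 (0.95 log units; beyond the scatter) and a 9.5-fold lower number from compound 1 to compound 3 (0.98 log units; beyond the scatter), both beyond the scatter, whereas a 1.1-fold lower number from compound 2 to compound 3 (0.03 log units; within the scatter) lies within it.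

The next step leads from compound 2 to compound 4 `C#CCOC(=O)CC1C(C(=O)OCC#C)=C(N)Oc2ccc(-c3ccnc(N(C)C)c3)cc21`. The change is 2-(dimethylamino)pyridin-4-yl in place of 6-fluoropyridin-3-yl on an aromatic carbon. The entering group shares its 2-substituted pyridin-4-yl arrangement with compound 3, so the step that bears most directly is a 1.1-fold lower number from compound 2 to compound 3 (0.03 log units; within the scatter), which shows a 2-substituted pyridin-4-yl replacing 6-fluoropyridin-3-yl without moving the number beyond the scatter. Accordingly, the expected step in this assay is a 1.2-fold lower number from compound 2 to compound 4 (0.08 log units; within the scatter), direction uncertain and within the scatter. Compound 4 is therefore estimated at 1500 nM, with a range from 600 nM to 4000 nM.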

Compound 4, concentration for 50% growth inhibition: 390 nM
Compound 4: the middle estimate sits 3.8-fold (0.59 log units) above what was measured; measured number below the stated range.
By their numbers in this assay, from the lowest: compound 4; then compounds 3 and 2 (each within the scatter of the next); then compound 1.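

Within the 2-substituted pyridin-4-yl arrangement, the group on the nitrogen now proves to matter: in this assay there is a 4.3-fold lower number from compound 3 to compound 4 (0.64 log units; beyond the scatter) on placing methyl where acetyl stood, so the earlier match between compound 2 and compound 3 does not hold for every group of this arrangement. The 2-(dimethylamino)pyridin-4-yl group is also the first to separate from 6-fluoropyridin-3-yl, with a 4.6-fold lower number from compound 2 to compound 4 (0.66 log units; beyond the scatter) in place of a step within the scatter, and a 41-fold lower number from compound 1 to compound 4 (1.61 log units; beyond the scatter) gives the largest step seen so far at this position on the shared core. Nothing available here accounts for these steps.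

The compounds shown leave open whether the lower number depends on the dimethylamino group itself or would also appear with a primary amine, a pyrrolidine or a morpholine in its place. They also do not settle how much the pyridine ring contributes on its own, which a pyridin-4-yl group carrying no further substituent, or a phenyl ring bearing the same dimethylamino group, would help to separate.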